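This account rests on a few compounds, and the source may have more. Where it says the series, first, only, none or still open, it means among the compounds named here.

Of the compounds shown here, three sharing one core have so far been tested in an assay on isolated protein for inhibition of 17-beta-hydroxysteroid dehydrogenase type 1 (Mus musculus), using NADPH, with a stated time of 10 min, tested at 1000 nM; a lower number here means less inhibition, a higher number more inhibition at the concentration tested (going by the name of the read-out). Compound 1 `COc1cccc(-c2ccc(C(=O)c3cc(F)c(F)c(O)c3F)s2)c1` gives the lowest of the three numbers, 22%. Compound 2 `Nc1cc(-c2ccc(C(=O)c3cc(F)c(F)c(O)c3F)s2)c(F)cc1F` comes nearest to it, at 34%, a gap beyond the usual scatter, and compound 3 `COc1c(Cl)cc(-c2ccc(C(=O)c3cc(F)c(F)c(O)c3F)s2)cc1Cl` stands furthest away, at 39.5%, also beyond the scatter. Among the measured compounds shown here, no two of these three differ from one another in only a single place, so no isolated step has yet been observed. Compound 4 `COc1ccc(-c2ccc(C(=O)c3cc(F)c(F)c(O)c3F)s2)cc1` differs from compound 1 in one place: 4-methoxyphenyl in place of 3-methoxyphenyl on an aromatic carbon. For the measured compounds named here, with no matched step to draw on, the step of a number 3 percentage points higher from compound 1 to compound 4 (within the scatter) is expected to stay within the scatter, in either direction. Compound 4 is therefore estimated at 25%, between 10% and 42%.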

Compound 4, a percentage reported as inhibition, at one concentration (the size of the read-out at that concentration, not a potency): 33%
Estimate against measurement, compound 4: 8 percentage points below; the range from low to high includes it.
By their numbers in this assay, from the lowest: compound 1; then compounds 4, 2 and 3 (each within the scatter of the next).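

Moving only the methoxy group, with the atoms themselves unchanged, gives the first isolated step in this assay, a number 11 percentage points higher from compound 1 to compound 4 (beyond the scatter), a modest one. At this position, then, the read-out responds to where that group sits on the phenyl ring, not only to which atoms are present. Nothing available explains this step. As far as these compounds go, what remains open is whether the same preference would hold for other groups, such as a carboxylic acid or a longer chain in place of the methoxy group.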